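Removal of the nitro group from compound 1

The compounds below may be only part of what the source reports. "The series", "measured", "known", "first", "only" and "open" are said of these compounds alone.

Measured in an ADME assay on L6 cells (Rattus norvegicus) for cytotoxicity, read by sulforhodamine B assay, with a stated time of 72 h; on this read-out higher numbers stand for weaker inhibition and lower numbers for stronger inhibition:
Compound 1 `O=C1C(Nc2ccccc2C(F)(F)F)=C(Nc2ccccc2C(F)(F)F)C(=O)c2c1cccc2[N+](=O)[O-]` gives 88000 nM.
Compound 2 `Cc1ccccc1NC1=C(Nc2ccccc2C)C(=O)c2c(cccc2[N+](=O)[O-])C1=O` gives 186000 nM.
Compound 3 `Cc1cccc(NC2=C(Nc3cccc(C)c3)C(=O)c3ccccc3C2=O)c1` reaches only a limit of the assay, > 450000 nM.

Among the two numbers, compound 1 holds the lower one, with compound 2 beyond the scatter above it. Compound 3 sits at the limit of > 450000 nM in this assay, at which 1 of the 3 values shown sits, and carries no nitro group, while compound 1 and compound 2 both do.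

Compound 4 `O=C1C(Nc2ccccc2C(F)(F)F)=C(Nc2ccccc2C(F)(F)F)C(=O)c2ccccc21` is unmeasured. It differs from compound 1 by hydrogen in place of nitro on an aromatic carbon. Going by the values given here, no measured pair covers this change directly. Among the compounds with values here, the only compound without the nitro group, compound 3, gives a limit, so the step in this assay is expected to raise the number, probably beyond the scatter, though the other substituents also differ there.

For compound 4 the expected value in this assay is 250000 nM, with a range from 90000 nM to 600000 nM, which corresponds to an expected step of a 2.8-fold higher number from compound 1 to compound 4 (0.45 log units; beyond the scatter).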

Compound 4, half-maximal inhibitory concentration: 292000 nM
For compound 4 the middle estimate is 1.2-fold (0.07 log units) below the measured one; the measured number falls inside the stated range.
By their numbers in this assay, from the lowest: compound 1; then compounds 2 and 4 (each within the scatter of the next). At a limit, above all of these: compound 3.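

Taking the nitro group off this aromatic carbon, with nothing else changed, gives in this assay a 3.3-fold higher number from compound 1 to compound 4 (0.52 log units; beyond the scatter). Going by these compounds alone, this is the first comparison that differs in one place, so the link between nitro and the lower number no longer rests on compounds whose other substituents also differ, although the step is modest. Compound 3 remains at a limit of the assay, which is not a number and enters no step: the limit of > 450000 nM in this assay, at which 1 of the 4 values shown sits.

Still open, on these data alone, is whether the same step recurs with methyl in place of trifluoromethyl, as the methyl-bearing compounds cannot show this without a matched pair. Also open, as far as these compounds go, is how an amine or a carboxylic acid on this aromatic carbon would compare with nitro and hydrogen.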